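A Smaller Group on the Carbonyl Carbon

A few compounds are considered here, and "the series" means these few. Any claim that something is new, unique, unknown or untested is made for them only; others in the source may bear on it.

Compound 2 `Cc1nc(S(C)(=O)=O)ccc1Oc1ncnc(OC2CCN(C(=O)OC(C)(C)CF)CC2)c1F` gives 19.9 nM in a functional assay on isolated protein for inhibition of Glucose-dependent insulinotropic receptor (Homo sapiens), read by HTRF and cAMP accumulation (a higher number here means that more compound is needed for the effect, a lower number that less compound is needed), and stands second highest of the three measured numbers: compound 1 `Cc1nc(S(C)(=O)=O)ccc1Oc1ncnc(OC2CCN(C(=O)OC(C)C)CC2)c1F` gives 21 nM, within the scatter of compound 2, while compound 3 `Cc1nc(S(C)(=O)=O)ccc1Oc1ncnc(OC2CCN(C(=O)SC(C)(C)C)CC2)c1F` gives 4.83 nM. The unmeasured compound 4 `Cc1nc(S(C)(=O)=O)ccc1Oc1ncnc(OC2CCN(C(=O)C(C)(C)F)CC2)c1F` differs from compound 2 at the carbonyl carbon: a group of 4 heavy atoms (3 carbon, 1 fluorine; no ring) in place of a group of 6 heavy atoms (4 carbon, 1 oxygen, 1 fluorine; no ring), on a carbonyl carbon. Within the data shown here, no measured step makes this exact change. The step of a 1.1-fold lower number from compound 1 to compound 2 (0.02 log units; within the scatter) shows that a fluoromethyl in place of hydrogen changes little, while a 4.1-fold lower number from compound 2 to compound 3 (0.61 log units; beyond the scatter) shows that exchanging the whole group on the carbonyl carbon can lower the number modestly. A small lowering, or none beyond the scatter, is therefore expected: a 1.4-fold lower number from compound 2 to compound 4 (0.15 log units; within the scatter). Compound 4 is estimated at 14 nM, ranging from 5 nM to 45 nM.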

Compound 4, half-maximal effective concentration: 76.3 nM
Beside the measured number, compound 4's estimate is 5.5-fold (0.74 log units) below it; measured number above the stated range.
By their numbers in this assay, from the lowest: compound 3; then compounds 2 and 1 (each within the scatter of the next); then compound 4.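

Among these compounds, putting 1-fluoro-1-methylethyl on the carbonyl carbon is the first change here that raises the number in this assay, with a 3.8-fold higher number from compound 2 to compound 4 (0.58 log units; beyond the scatter) and a 3.6-fold higher number from compound 1 to compound 4 (0.56 log units; beyond the scatter). The gap to the sulfur-linked group is larger, with a 16-fold higher number from compound 3 to compound 4 (1.20 log units; beyond the scatter), so the group on this carbonyl carbon can move the number in either direction. Nothing available explains this rise.

The compounds shown leave open whether the fluorine or the direct carbon link to the carbonyl carbon matters more. A plain tert-butyl group or a tert-butylamino group at this place would help separate the two.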